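Taking the dimethylamino group off compound 1

The source may hold more compounds than are shown below. What is called first, only, known or untested is meant among the compounds shown, and "the series" means these compounds.

Measured so far in a functional assay on A2780 cells (Homo sapiens) for inhibition, read by sulforhodamine B assay; on this read-out lower numbers stand for stronger inhibition of growth and higher numbers for weaker inhibition of growth:
compound 1 `Cc1ccc2[nH]c(-c3ccc(-c4ccc(-c5ccc(N(C)C)cc5)cc4)cc3)nc2c1` gives 2210 nM
compound 2 `CN(C)c1ccc(-c2ccc(-c3ccc(-c4nc5ccccc5[nH]4)cc3)cc2)cc1` gives 100000 nM

Compound 1 holds the lower of these two numbers, and the gap to compound 2 lies beyond the scatter. Compound 3 `Cc1ccc2[nH]c(-c3ccc(-c4ccc(-c5ccccc5)cc4)cc3)nc2c1` has not yet been measured. It differs from compound 1 by hydrogen in place of dimethylamino on an aromatic carbon, para to a large group (hydrogen in place of dimethylamino on an aromatic carbon), which turns 4-(dimethylamino)phenyl into phenyl. For the measured compounds named here, only one measured step bears on this, and only indirectly, since it is a different change: hydrogen in place of methyl on an aromatic carbon gave a 45-fold higher number from compound 1 to compound 2 (1.66 log units; beyond the scatter). That large loss shows how sensitive compound 1 is, so a higher number is expected in this assay, though probably a smaller step than that one. The expected change is a 4.1-fold higher number from compound 1 to compound 3 (0.61 log units; beyond the scatter). For compound 3 the estimated value is 9000 nM, within an expected range of 2500 nM to 50000 nM.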

Compound 3, concentration for 50% growth inhibition: 41200 nM
For compound 3 the middle estimate is 4.6-fold (0.66 log units) below the measured one, and the stated range covers the measured number.
By their numbers in this assay, from the lowest: compound 1; then compound 3; then compound 2.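

In this assay, putting hydrogen in place of dimethylamino on this aromatic carbon gives a 19-fold higher number from compound 1 to compound 3 (1.27 log units; beyond the scatter), so the dimethylamino group, and not only the methyl group, counts towards the growth inhibition seen with compound 1. Read beside a 45-fold higher number from compound 1 to compound 2 (1.66 log units; beyond the scatter), this shows a large loss after a change at either of two separate places in compound 1. Nothing available explains the loss at this position.

On these data alone, it remains open whether another group on this carbon, such as a primary amine, a methoxy group or a diethylamino group, would keep the growth inhibition of compound 1. Also open, as far as these compounds go, is how the removal of dimethylamino would read in a compound that already lacks the methyl group, as compound 2 does.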